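Sulfur substituent change at the five-membered ring of compound 2

The source may hold more compounds than are shown below. What is called first, only, known or untested is meant among the compounds shown, and "the series" means these compounds.

Measured so far:
compound 1 `CC(C)n1c([S+]([O-])c2ccccc2)nc2cnc(Nc3ccc(N4CCN(C)CC4)cc3)nc21` gives 215 nM;
compound 2 `CN1CCN(c2ccc(Nc3ncc4nc([S+]([O-])Cc5cccnc5)n(C5CCOCC5)c4n3)cc2)CC1` gives > 10000 nM in a functional assay on HCC827 cells (Homo sapiens) for antiproliferative activity, read by MTT assay, with a stated time of 72 h (a lower number here means a stronger inhibitor, a higher number a weaker inhibitor), which is a limit of the assay;
compound 3 `CN1CCN(c2ccc(Nc3ncc4nc([S+]([O-])Cc5cccnc5)n(C5CCCC5)c4n3)cc2)CC1` gives 2350 nM.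

Compound 2 thus sits at the limit, the weakest point shown (the limit of > 10000 nM in this assay, at which 1 of the 3 values shown sits). Compound 4 `CN1CCN(c2ccc(Nc3ncc4nc(Sc5ccccc5)n(C5CCOCC5)c4n3)cc2)CC1` differs from compound 2 at the sulfur-bearing position: a group of 7 heavy atoms (6 carbon, 1 sulfur; one six-membered aromatic ring of carbon only) in place of a group of 9 heavy atoms (6 carbon, 1 nitrogen, 1 oxygen, 1 sulfur; one six-membered aromatic ring with 1 hetero atom), on an aromatic carbon. Among the compounds with values here, the only measured step, an at least 4.2-fold lower number from compound 2 to compound 3 (0.62 log units; beyond the scatter), concerns the oxan-4-yl group on the aromatic nitrogen, not this position, so no measured step bears directly on it. Compound 1, which carries phenylsulfinyl with a different nitrogen substituent, gives 215 nM. A step of an at least 6.6-fold lower number from compound 2 to compound 4 (0.82 log units; beyond the scatter) toward stronger inhibition is therefore expected, with wide uncertainty. Compound 4 is estimated at 1500 nM, within 300 nM to 10000 nM.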

Compound 4, half-maximal inhibitory concentration: 42.6 nM
Compound 4: middle estimate off by 35-fold (1.55 log units), on the high side; measured number below the stated range.
By their numbers in this assay, from the lowest: compound 4; then compound 1; then compound 3. At a limit, above all of these: compound 2.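

Phenylsulfanyl in place of the group of 9 heavy atoms gives an at least 230-fold lower number from compound 2 to compound 4 (2.37 log units; beyond the scatter) in this assay, so this position, untouched by the earlier step, has a large bearing on the read-out. The size of the step is only a lower bound, since compound 2 stands at a limit: the limit of > 10000 nM in this assay, at which 1 of the 4 values shown sits.

The sulfur link and the aromatic ring change together in this single step, so their separate shares remain unresolved. Also open, as far as these compounds go, is whether an amine or a short alkyl chain on this aromatic carbon would keep the activity of compound 4.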